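A halogen swap on the shared core: from bromo to fluoro

The source may hold more compounds than are shown below. What is called first, only, known or untested is meant among the compounds shown, and "the series" means these compounds.

Measured so far:
- Compound 1, `N#CC1=C(N)OC(c2c[nH]c3ccccc23)=C(C#N)C1c1ccc(Br)cc1`: 10.6%
- Compound 2, `Cc1ccc(C2C(C#N)=C(N)OC(c3c[nH]c4ccccc34)=C2C#N)cc1`: 6.2%
- Compound 3, `N#CC1=C(N)OC(c2c[nH]c3ccccc23)=C(C#N)C1c1ccccc1Cl`: 14.5%

In a functional assay, tested at 200 ug/mL (on this read-out higher numbers stand for a stronger effect at the one concentration tested and lower numbers for a weaker effect), compound 1 gives 10.6%, the second highest of the three numbers; its nearest neighbour is compound 3 and its furthest is compound 2, and both gaps lie within the scatter, so no order among the three can be claimed.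

Compound 4, `N#CC1=C(N)OC(c2c[nH]c3ccccc23)=C(C#N)C1c1ccc(F)cc1`, has not been measured. It differs from compound 1 in one place: fluoro in place of bromo on an aromatic carbon. Read one bond further out, this is 4-bromophenyl to 4-fluorophenyl.

Within the data shown here, only one measured step touches the same aromatic carbon: a number 4.4 percentage points lower from compound 1 to compound 2 (within the scatter). The other two steps, a number 3.9 percentage points higher from compound 1 to compound 3 (within the scatter) and a number 8.3 percentage points higher from compound 2 to compound 3 (within the scatter), move the substituent to another position and are also within the scatter. Every exchange made so far on this phenyl ring has left this assay essentially unchanged, so a small halogen for a larger one at the same place is expected to do the same.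

For compound 4 the expected result is 9%, with a range of 2% to 18%; the expected step from compound 1 is a number 1.6 percentage points lower from compound 1 to compound 4 (within the scatter), none beyond the scatter.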

Compound 4, a percentage reported as activity, at one concentration (the size of the read-out at that concentration, not a potency): 22.4%
The estimate for compound 4 lay 13.4 percentage points below the measured number; measured number above the stated range.
By their numbers in this assay, from the lowest: compounds 2, 1, 3 and 4 (each within the scatter of the next, the first and the last beyond it).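

In this assay, the aromatic carbon carrying the halogen is no longer silent: fluoro in place of bromo gives a number 11.8 percentage points higher from compound 1 to compound 4 (beyond the scatter), and fluoro in place of methyl gives a number 16.2 percentage points higher from compound 2 to compound 4 (beyond the scatter). Among these compounds, these are the first steps at this carbon to clear the scatter, although both are only modest. The comparison with the 2-chlorophenyl group gives a number 7.9 percentage points higher from compound 3 to compound 4 (within the scatter), so compound 3 and compound 4 cannot be put in order, and no measurement at hand offers an explanation for any of these steps.

Going by these compounds, it remains open whether the gain is specific to fluoro or would also appear with another group on this carbon, such as methoxy or an amine. On these data alone, it is also open whether compound 4 would keep its place at other concentrations, as a single-concentration read-out is not a potency.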